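The source may hold more compounds than are shown below. What is called first, only, known or untested is meant among the compounds shown, and "the series" means these compounds.

In a physicochemical assay for solubility, using the shake flask method, in phosphate buffer, measured as kinetic solubility, with a stated time of 20 h, at pH 6.5 (on this read-out lower numbers stand for lower solubility and higher numbers for higher solubility), compound 2 (`FC(F)(F)c1ccc(Nc2cc3[nH]c(CC4CC4)nc3cn2)nc1`) gives 118000 nM and compound 3 (`FC1(F)CCC(c2nc3cnc(Nc4ccc(C(F)(F)F)cn4)cc3[nH]2)CC1`) gives 99000 nM on the same scale. The step between them, 4,4-difluorocyclohexyl in place of cyclopropylmethyl on an aromatic carbon, is a 1.2-fold lower number from compound 2 to compound 3 (0.08 log units; within the scatter) and sets no order between the two. Compound 1 (`Fc1ccc(Nc2cc3[nH]c(-c4ccc(F)c(F)c4)nc3cn2)nc1`) returns < 5000 nM which is a limit of the assay and not a number.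

Compound 4 (`Fc1ccc(Nc2cc3[nH]c(C4CCC(F)(F)CC4)nc3cn2)nc1`) has fluoro in place of trifluoromethyl on an aromatic carbon and otherwise matches compound 3. For the measured compounds named here, no measured step covers this exchange. Going by the values given here, the only measured step (a 1.2-fold lower number from compound 2 to compound 3 (0.08 log units; within the scatter)) changes a different group. Compound 1 carries the same fluoro but has a different group elsewhere on the core, so its limit cannot be carried over to compound 4. No step beyond the scatter is therefore expected, and the estimated step is a 1.0-fold higher number from compound 3 to compound 4 (0.00 log units; within the scatter) with wide uncertainty. For compound 4 the estimated value is 100000 nM with an expected range from 30000 nM to 250000 nM in this assay when it is measured.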

Compound 4, solubility: 170000 nM
Estimate against measurement, compound 4: 1.7-fold (0.23 log units) below; low and high end bracket the measured number.
By their numbers in this assay, from the lowest: compounds 3, 2 and 4 (each within the scatter of the next). At a limit, below all of these: compound 1.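

With 4,4-difluorocyclohexyl held fixed, fluoro in place of trifluoromethyl gives a 1.7-fold higher number from compound 3 to compound 4 (0.23 log units; within the scatter) in this assay, so this exchange, on an aromatic carbon two atoms from the ring nitrogen, sets no order between the two compounds. With fluoro held fixed, 4,4-difluorocyclohexyl in place of 3,4-difluorophenyl gives an at least 34-fold higher number from compound 1 to compound 4 (1.53 log units; beyond the scatter), the only step shown that lies beyond the scatter, so here the larger difference goes with the other group and not with this position. That step starts from a limit and not from a number, and compound 1 stands at it: the limit of < 5000 nM in this assay, at which 1 of the 4 values shown sits.

Left open is how a nitrile or an amine would read at this position. Also open, as far as these compounds go, is whether the step from 3,4-difluorophenyl to 4,4-difluorocyclohexyl would recur with trifluoromethyl in place of fluoro.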